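Fluoro for hydrogen on an aromatic carbon: compound 4

The compounds below may be only part of what the source reports. "The series", "measured", "known", "first", "only" and "open" are said of these compounds alone.

Compound 1, `O=C(Nc1ccc(-c2cscn2)cc1)C1CCCN(Cc2cccc(F)c2)C1`, is measured in a functional assay on A-375 cells (Homo sapiens) for antiproliferative activity (on this read-out higher numbers stand for weaker inhibition and lower numbers for stronger inhibition), where compound 1 gives 2450 nM. Compound 2, `O=C(Nc1ccc(-c2cscn2)cc1)C1CCCN(Cc2cccc(F)c2F)C1`, differs from compound 1 by fluoro in place of hydrogen on an aromatic carbon; in this assay compound 2 gives 1480 nM, and the step is a 1.7-fold lower number from compound 1 to compound 2 (0.22 log units; within the scatter). Compound 3, `O=C(Nc1ccc(-c2ccc[nH]2)cc1)[C@H]1CCCN(Cc2ccc(F)c(F)c2)C1`, carries a different core; the difference between the core of compound 3 and the core of compound 1 is not broken down here. In this assay compound 3 gives 190 nM, the lowest of the three numbers, and its gaps to compound 2 and to compound 1 both lie beyond the scatter.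

Compound 4, `O=C(Nc1ccc(-c2ccc[nH]2)cc1F)[C@H]1CCCN(Cc2ccc(F)c(F)c2)C1`, is not yet measured. It differs from compound 3 by fluoro in place of hydrogen on an aromatic carbon. Within the data shown here, this is the same kind of change as the one from compound 1 to compound 2, but not the same: in compound 2 the entering fluoro sits ortho to a fluoro group and ortho to a large group, whereas in compound 4 it sits ortho to a large group and meta to a 1H-pyrrol-2-yl group.

The step from compound 3 to compound 4 is expected to be small, a 1.3-fold lower number from compound 3 to compound 4 (0.10 log units; within the scatter), since the same kind of change gave a 1.7-fold lower number from compound 1 to compound 2 (0.22 log units; within the scatter) within the scatter. For compound 4 in this assay the estimate is 150 nM, with the expected range running from 60 nM to 500 nM. Among the measured compounds shown here, the surroundings of the change differ from the one precedent, so the range is kept wide.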

Compound 4, half-maximal inhibitory concentration: 130 nM
Estimate against measurement, compound 4: 1.2-fold (0.06 log units) above, within the range that was stated.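

In this assay the new step is a 1.5-fold lower number from compound 3 to compound 4 (0.16 log units; within the scatter), so on this second core too, fluoro in place of hydrogen on an aromatic carbon gives no step beyond the scatter. Set beside the earlier case, the two steps do not differ: the same change on two cores in this assay, a 1.7-fold lower number (0.22 log units; within the scatter) from compound 1 to compound 2 and a 1.5-fold lower number (0.16 log units; within the scatter) from compound 3 to compound 4, 1.1-fold (0.05 log units) apart, within the scatter of two such steps This shows only that the change gave a step within the scatter in both of the two cases available; it does not show that the change has a real effect on either core, and with the entering fluoro in compound 4 ortho to a large group and meta to a 1H-pyrrol-2-yl group, a setting unlike that in compound 2, core and place of the change are not separated.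

The compounds shown leave open what fluoro does at the matching place on the core of compound 1, and at the matching place on the core of compound 3 for the change seen in compound 2. Also open, from the compounds shown here alone, is whether another group at the place of the fluoro in compound 4, such as chloro, methoxy or an amine, would give a step beyond the scatter.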